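Ring-nitrogen substituent variation on the shared core

The compounds below may be only part of what the source reports. "The series", "measured", "known", "first", "only" and "open" are said of these compounds alone.

Three measured compounds share one core, shown for compound 1 as `CCCCn1c(SCc2cc([N+](=O)[O-])ccc2OC)nc2cc(NC(=O)NC(C)(C)C)ccc21`, and differ only in the group on the ring nitrogen. In an assay on isolated protein for inhibition of Gonadotropin-releasing hormone receptor (Rattus norvegicus) (on this read-out higher numbers stand for weaker inhibition and lower numbers for stronger inhibition), compound 1 gives 330 nM. Compound 2 `COCCn1c(SCc2cc([N+](=O)[O-])ccc2OC)nc2cc(NC(=O)NC(C)(C)C)ccc21` gives 280 nM in this assay, and the step of a 1.2-fold lower number from compound 1 to compound 2 (0.07 log units; within the scatter). Compound 3 `COc1ccc([N+](=O)[O-])cc1CSc1nc2cc(NC(=O)NC(C)(C)C)ccc2n1Cc1ccccn1` gives 670 nM in this assay, the highest number of the three, with both other compounds lying beyond the scatter below it.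

Compound 4 `COc1ccc([N+](=O)[O-])cc1CSc1nc2cc(NC(=O)NC(C)(C)C)ccc2n1-c1ccccc1` is not yet measured. Its change from compound 3 is phenyl in place of (pyridin-2-yl)methyl on an aromatic nitrogen. Among the compounds with values here, the steps that bear on it are a 2.0-fold higher number from compound 1 to compound 3 (0.31 log units; beyond the scatter) and a 2.4-fold higher number from compound 2 to compound 3 (0.38 log units; beyond the scatter), both modest and both raising the number when the group on the ring nitrogen was changed to the (pyridin-2-yl)methyl of compound 3. Within the data shown here, no measured step places an aromatic ring directly on that nitrogen, so the direction for compound 4 cannot be read from the series; the size of the effect seen so far suggests a modest step at most, either way.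

Compound 4 is therefore expected to sit close to compound 3, with the estimated step of a 1.2-fold lower number from compound 3 to compound 4 (0.09 log units; within the scatter). For compound 4 the estimate in this assay is 550 nM, with a range from 180 nM to 1700 nM.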

Compound 4, half-maximal inhibitory concentration: > 2600 nM
Compound 4: no number, only a limit; the forecaster's own chance of this, stated with the estimate: 5%; at least 4.7-fold (0.67 log units) between middle value and limit.
By their numbers in this assay, from the lowest: compounds 2 and 1 (each within the scatter of the next); then compound 3. At a limit, above all of these: compound 4.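

Compound 4 is the only compound shown with an aromatic ring set directly on the ring nitrogen, with no saturated chain carbon linking the two, and its read-out in this assay is a limit and not a number: the limit of > 2600 nM in this assay, at which 1 of the 4 values shown sits.

The steps into it are an at least 3.8-fold higher number from compound 3 to compound 4 (0.58 log units; beyond the scatter), an at least 9.2-fold higher number from compound 2 to compound 4 (0.96 log units; beyond the scatter) and an at least 7.8-fold higher number from compound 1 to compound 4 (0.89 log units; beyond the scatter), all beyond the scatter and each larger than any step among compound 1, compound 2 and compound 3. The earlier compounds shown here showed only that butyl, 2-methoxyethyl and (pyridin-2-yl)methyl stay within a narrow span of numbers, whereas phenyl on the nitrogen itself falls clearly outside that span.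

The change from compound 3 to compound 4 removes the chain carbon and the ring nitrogen of the pyridine together, so the compounds shown cannot separate the two; a benzyl group on the ring nitrogen would do so. Also open, on these data alone, are how far the true value of compound 4 lies past its limit and how a pyridin-2-yl ring bound directly to the nitrogen, or a 2-aminoethyl chain, would read.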